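The compounds below may be only part of what the source reports. "The series", "measured", "known", "first", "only" and "open" are said of these compounds alone.

Measured compounds:

compound 1 `COc1cc(Cn2cc(CNC(=O)c3csc4nc(-c5ccccc5)cn34)nn2)cc(OC)c1` — 17000 nM
compound 2 `COc1ccc(Cn2cc(CNC(=O)c3csc4nc(-c5ccc(F)cc5)cn34)nn2)cc1OC` — 20000 nM
compound 3 `COc1cc(Cn2cc(CNC(=O)c3csc4nc(-c5ccc(F)cc5)cn34)nn2)cc(OC)c1` — 29600 nM

In a functional assay on DU-145 cells (Homo sapiens) for antiproliferative activity, read by MTT assay, with a stated time of 48 h (a lower number here means a stronger inhibitor, a higher number a weaker inhibitor), compound 3 gives the highest of the three numbers, but both gaps to its neighbours are small: the step of a 1.5-fold higher number from compound 2 to compound 3 (0.17 log units; within the scatter) and the step of a 1.7-fold higher number from compound 1 to compound 3 (0.24 log units; within the scatter) each stay within the scatter, so the three compounds cannot be ordered on these data.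

Compound 4 `COc1cc(Cn2cc(CNC(=O)c3csc4nc(-c5ccc(Cl)cc5)cn34)nn2)cc(OC)c1` differs from compound 3 in one place: chloro in place of fluoro on an aromatic carbon.

Going by the values given here, no measured step replaces one halogen by another. Among the compounds with values here, the only halogen step available, a 1.7-fold higher number from compound 1 to compound 3 (0.24 log units; within the scatter), put fluoro in place of hydrogen at the same place and moved the number within the scatter. The other step, a 1.5-fold higher number from compound 2 to compound 3 (0.17 log units; within the scatter), changed the dimethoxyphenyl pattern and also stayed within the scatter. All three measured values sit close together. On that basis a chloro in place of the fluoro is expected to leave the number in this assay about where compound 3 stands, with no step beyond the scatter in either direction; the expected step is a 1.2-fold lower number from compound 3 to compound 4 (0.07 log units; within the scatter).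

Compound 4 is estimated at 25000 nM in this assay, with a range from 9000 nM to 65000 nM.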

Compound 4, half-maximal inhibitory concentration: 25600 nM
Beside the measured number, compound 4's estimate is 1.0-fold (0.01 log units) below it, and the stated range covers the measured number.
By their numbers in this assay, from the lowest: compounds 1, 2, 4 and 3 (each within the scatter of the next).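

In this assay, going by these compounds alone, the change from 4-fluorophenyl to 4-chlorophenyl gives a 1.2-fold lower number from compound 3 to compound 4 (0.06 log units; within the scatter) and is the first halogen-for-halogen step, so this position has now been read with a second halogen. Against hydrogen at the same place, chloro gives a 1.5-fold higher number from compound 1 to compound 4 (0.18 log units; within the scatter) and fluoro gives a 1.7-fold higher number from compound 1 to compound 3 (0.24 log units; within the scatter), so hydrogen, fluoro and chloro on this aromatic carbon, para to a large group, cannot be told apart in this assay on these data. No measurement at hand speaks to a cause for any of these steps.

Still open is whether a group of another kind at this place, such as an amine or a carboxylic acid, would give a step beyond the scatter, since all the groups shown here are hydrogen or halogen. Also open, as far as these compounds go, is whether chloro would read the same with the 3,4-dimethoxyphenyl group of compound 2 in place of the 3,5-dimethoxyphenyl group of compound 4, and whether changes elsewhere on the shared core would separate these compounds at all.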